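Aryl substituent swap at the shared core: compound 4

This account rests on a few compounds, and the source may have more. Where it says the series, first, only, none or still open, it means among the compounds named here.

Three analogues sharing one core have been run in an assay for inhibition of inositol hexakisphosphate kinase 3 (Homo sapiens), read by colorimetric assay, coupled enzyme assay and malachite green, with a stated time of 120 min, in the presence of a further agent that is not named here; a lower number here means a stronger inhibitor, a higher number a weaker inhibitor. Compound 1 `O=C(O)c1ccc2noc(-c3ccc(-c4ccncc4)cc3)c2c1` gives 670 nM, compound 2 `O=C(O)c1ccc2noc(-c3ccc(Cc4ccccc4)cc3)c2c1` gives 1290 nM, and compound 3 `O=C(O)c1ccc2noc(-c3ccc(N4CCCC4=O)cc3)c2c1` gives 2170 nM. Going by the values given here, compound 3 carries the highest of the three numbers, but the gap between compound 2 and compound 3 a 1.7-fold higher number from compound 2 to compound 3 (0.23 log units; within the scatter) lies within the scatter; only the step between compound 1 and compound 3 a 3.2-fold higher number from compound 1 to compound 3 (0.51 log units; beyond the scatter) is beyond it, and even that is modest. The step from compound 1 to compound 2 a 1.9-fold higher number from compound 1 to compound 2 (0.28 log units; within the scatter) is also within the scatter.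

Compound 4 `O=C(O)c1ccc2noc(-c3ccc(NC(=O)c4ccncn4)cc3)c2c1` is the next analogue. Its change from compound 3 is ((pyrimidin-4-yl)carbonyl)amino in place of 2-oxopyrrolidin-1-yl on an aromatic carbon. Among the compounds with values here, no measured pair covers this exchange. The nearest guide is the step from compound 1 to compound 3 a 3.2-fold higher number from compound 1 to compound 3 (0.51 log units; beyond the scatter), where loss of a six-membered aromatic ring with one hetero atom raised the number modestly; compound 4 brings back a six-membered aromatic ring with two hetero atoms, now through an amide, so a small move back toward the number of compound 1 is the expectation, though the change is larger than any measured one and the direction is uncertain.

For compound 4 in this assay the expected step from compound 3 is a 1.7-fold lower number from compound 3 to compound 4 (0.22 log units; within the scatter). Compound 4 is therefore estimated at 1300 nM, with a range from 450 nM to 3800 nM.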

Compound 4, half-maximal inhibitory concentration: 430 nM
Compound 4: middle estimate off by 3.0-fold (0.48 log units), on the high side; measured number below the stated range.
By their numbers in this assay, from the lowest: compounds 4, 1, 2 and 3 (each within the scatter of the next, the first and the last beyond it).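

In this assay the ((pyrimidin-4-yl)carbonyl)amino group gives the largest step yet seen at this position on the aromatic carbon para to a large group, with a 5.0-fold lower number from compound 3 to compound 4 (0.70 log units; beyond the scatter) and also a 3.0-fold lower number from compound 2 to compound 4 (0.48 log units; beyond the scatter) as both beyond the scatter. The exchange against pyridin-4-yl, a 1.6-fold lower number from compound 1 to compound 4 (0.19 log units; within the scatter) within the scatter, places the amide-linked group of compound 4 level with the directly attached ring of compound 1, so this position takes a substituent of 9 heavy atoms without loss against the best earlier analogue. Nothing in the data on hand accounts for the size of these steps.

The compounds shown leave open whether the amide hydrogen or the ring nitrogens of the pyrimidin-4-yl group carry the step from compound 3, a question that an amide with a methyl group on its nitrogen or a plain benzoylamino group would separate. From the compounds shown here alone, they also hold the carboxylic acid on the shared core constant throughout, so how a methyl ester or a tetrazole there would read alongside this amide stays open.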